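The source may report more compounds than this note shows. Statements on the series, on what has been measured and on what is new or still open speak of the compounds shown alone.

In a functional assay on SW-620 cells (Homo sapiens) for inhibition, read by MTT assay, with a stated time of 4 days (on this read-out lower numbers stand for stronger inhibition and higher numbers for weaker inhibition), compound 1 (`COc1cc(NC(C)CCCNC(=O)NNC(=O)NCCCCCO)c2ncccc2c1`) gives > 100000 nM, which is a limit of the assay and not a number. As far as these compounds go, it therefore sits at the weak end of what this test can report, and its true value is unknown. Compound 2 (`COc1cc(NC(C)CCCNC(=O)NNC(=O)Nc2ccc(Cl)c(C(F)(F)F)c2)c2ncccc2c1`) gives a real number, 15000 nM.

Compound 3 (`COc1cc(NC(C)CCCNC(=O)NN)c2ncccc2c1`) keeps the core of compound 1 but loses one end of the molecule: hydrogen in place of (5-hydroxypentyl)carbamoyl on an amine nitrogen. In words, this is hydrogen in place of (5-hydroxypentyl)carbamoyl on an amine nitrogen.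

Among the compounds with values here, only one measured step bears on this change, an at least 6.6-fold lower number from compound 1 to compound 2 (0.82 log units; beyond the scatter). That step swapped just the 5-hydroxypentyl group, while here the whole (5-hydroxypentyl)carbamoyl group leaves, so it is only a loose guide. It does show that changes at this end of the molecule can move the number beyond the scatter. A modest shift towards a lower number, meaning stronger inhibition, therefore seems likely, though compound 3 could also stay at the limit.

The expected size of the change is an at least 2.5-fold lower number from compound 1 to compound 3 (0.39 log units; beyond the scatter). The estimate for compound 3 is 40000 nM, with an expected range of 12000 nM to 100000 nM.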

Compound 3, half-maximal inhibitory concentration: > 100000 nM
Compound 3 gave a limit, no number (the forecaster's own chance of this, stated with the estimate: 30%); middle value at least 2.5-fold (0.39 log units) away from the limit.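

Compound 1 and compound 3 each give only a limit of the assay and not a number, so the step between them cannot be read: the limit of > 100000 nM in this assay, at which 2 of the 3 values shown sit. The compounds shown leave open whether hydrogen in place of (5-hydroxypentyl)carbamoyl changes inhibition at all and, if it does, in which direction and by how much.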